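The compounds below may be only part of what the source reports. "The series", "measured", "known", "first", "only" and "open" are said of these compounds alone.

Measured so far in a functional assay on A-375 cells (Homo sapiens) for antiproliferative activity, read by CCK-8 assay, with a stated time of 72 h, tested at 2 uM; on this read-out lower numbers stand for a weaker effect and higher numbers for a stronger effect at the one concentration tested:

- compound 1, `Nc1ccccc1NC(=O)c1ccc(CSC(=S)N2CCN(c3cccnc3)CC2)cc1`: 40.5%
- compound 2, `CN1CCN(C(=S)SCc2ccc(C(=O)Nc3ccccc3N)cc2)CC1`: 36.6%

For the measured compounds named here, compound 2 holds the lowest of the two numbers, but its only neighbour is compound 1, and the step of a number 3.9 percentage points lower from compound 1 to compound 2 (within the scatter) is within the scatter, so the two compounds cannot be separated on this read-out.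

The next compound, compound 3, `Nc1ccccc1NC(=O)c1ccc(CSC(=S)N2CCN(c3ncccn3)CC2)cc1`, is not yet measured. It differs from compound 2 in one place: pyrimidin-2-yl in place of methyl on an amine nitrogen in a ring. Going by the values given here, the only measured step that bears on this position is the one from compound 1 to compound 2, where pyridin-3-yl gave way to methyl on the same amine nitrogen in a ring, and that step, a number 3.9 percentage points lower from compound 1 to compound 2 (within the scatter), did not leave the scatter. Going back from methyl to a six-membered aromatic ring with two hetero atoms is therefore expected to give a step of the same modest kind in this assay, with no direction beyond the scatter; the expected step is a number 2.4 percentage points higher from compound 2 to compound 3 (within the scatter).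

For compound 3 the estimate in this assay is 39%, with a range from 27% to 52%.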

Compound 3, a percentage reported as inhibition, at one concentration (the size of the read-out at that concentration, not a potency): 24%
The estimate for compound 3 lay 15 percentage points above the measured number, and the stated range ends above it.
By their numbers in this assay, from the lowest: compound 3; then compounds 2 and 1 (each within the scatter of the next).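

In this assay, the group on this amine nitrogen in a ring can matter: pyrimidin-2-yl in place of methyl gives a number 12.6 percentage points lower from compound 2 to compound 3 (beyond the scatter) and so leaves the scatter, which the earlier step did not do. Pyrimidin-2-yl in place of pyridin-3-yl gives a number 16.5 percentage points lower from compound 1 to compound 3 (beyond the scatter) with the same ring position and the same shared core, so the two six-membered aromatic rings are not interchangeable here, and a six-membered aromatic ring on this nitrogen does not by itself set the read-out, given that compound 1 and compound 2 cannot be separated. No measurement at hand bears on why pyrimidin-2-yl stands apart from the other two groups.

The compounds shown leave open whether the lower number belongs to pyrimidin-2-yl alone or would also appear with other rings on this nitrogen, such as phenyl or pyridin-2-yl, and whether an open chain such as ethyl would stay with methyl. On these data alone, all three numbers rest on a single concentration, so they tell only of a stronger or weaker effect at that concentration, and how the compounds would compare at other concentrations stays open.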